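A few compounds are considered here, and "the series" means these few. Any claim that something is new, unique, unknown or untested is made for them only; others in the source may bear on it.

Measured compounds:
compound 1, `NS(=O)(=O)c1ccc(Nc2ncc(F)c(Nc3nc4ccccc4s3)n2)cc1`: > 50000 nM
compound 2, `COc1ccc2nc(Nc3nc(Nc4ccc(S(N)(=O)=O)cc4)ncc3C)sc2c1`: > 50000 nM

In a functional assay on MCF7 cells (Homo sapiens) for antiproliferative activity, read by MTT assay, with a stated time of 48 h (on this read-out higher numbers stand for weaker inhibition and lower numbers for stronger inhibition), compound 2 gives only a limit of the assay, > 50000 nM. Compound 1 likewise gives only a limit in this assay, > 50000 nM. Hence the limit of > 50000 nM in this assay, at which 2 of the 2 values shown sit: no measurable number exists for either, and compound 2 stands at the limit with no ordering possible against compound 1.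

Compound 3, `COc1ccc2nc(Nc3nc(Nc4ccc(S(N)(=O)=O)cc4)ncc3F)sc2c1`, is not yet measured. It differs from compound 2 by fluoro in place of methyl on an aromatic carbon. Among the measured compounds shown here, no measured step carries this exchange, and the only two values seen, both from compounds at the limit, give no sign that a measurable number will appear. The expected step in this assay, a step that the limit leaves unreadable from compound 2 to compound 3, is none beyond the scatter, with a second limit the most likely report. Compound 3 is therefore estimated at 60000 nM, in a range from 20000 nM to 200000 nM.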

Compound 3, half-maximal inhibitory concentration: > 50000 nM
Compound 3 ended at the assay's limit (the forecaster's own chance of this, stated with the estimate: 80%); the middle value does not contradict the limit.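

No step can be read from compound 2 to compound 3 or from compound 1 to compound 3 in this assay; all three compounds give only a limit: the limit of > 50000 nM in this assay, at which 3 of the 3 values shown sit.

The compounds shown leave open whether fluoro in place of methyl, or methoxy in place of hydrogen, changes the read-out in this assay at all.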